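The source may hold more compounds than are shown below. What is called first, only, known or untested is meant among the compounds shown, and "the series" means these compounds.

Series notes, aryl thiosemicarbazones on a shared core. Among the compounds with values here, compound 3 `CC1=CC[C@H](C(C)(C)NC(=S)N/N=C/c2ccc(Cl)cc2)CC1` stands second highest of the three numbers measured so far: in a functional assay on NCI/ADR-RES cells (Homo sapiens) for inhibition, read by sulforhodamine B assay, with a stated time of 48 h (on this read-out higher numbers stand for weaker inhibition of growth and lower numbers for stronger inhibition of growth), compound 3 gives 65200 nM. Its nearest neighbour is compound 2 `CC1=CC[C@H](C(C)(C)NC(=S)N/N=C/c2cccc(Cl)c2)CC1`, which in this assay gives 67500 nM; the step of a 1.0-fold lower number from compound 2 to compound 3 (0.02 log units; within the scatter) lies within the scatter. Furthest away is compound 1 `CC1=CC[C@H](C(C)(C)NC(=S)N/N=C/c2ccccc2O)CC1`, which in this assay gives 3700 nM; the step of an 18-fold higher number from compound 1 to compound 3 (1.25 log units; beyond the scatter) is large, as is the parallel step an 18-fold higher number from compound 1 to compound 2 (1.26 log units; beyond the scatter).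

Compound 4 `CC1=CC[C@H](C(C)(C)NC(=S)N/N=C/c2ccco2)CC1` is the next step from compound 3: furan-2-yl in place of 4-chlorophenyl on a carbon with a double bond to nitrogen. Within the data shown here, no measured step exchanges a six-membered aromatic ring of carbon only for a five-membered aromatic ring with one hetero atom, so what bears on it is indirect. The step of a 1.0-fold lower number from compound 2 to compound 3 (0.02 log units; within the scatter) shows that exchanging 3-chlorophenyl for 4-chlorophenyl changes nothing beyond the scatter, while the steps of an 18-fold higher number from compound 1 to compound 3 (1.25 log units; beyond the scatter) and an 18-fold higher number from compound 1 to compound 2 (1.26 log units; beyond the scatter) show that the 2-hydroxyphenyl ring of compound 1 gives a much lower number than either chlorophenyl ring. Compound 4 carries neither a chlorine nor a hydroxyl, and the change is unanchored by a measured step. For compound 4 the expected step is a 1.3-fold lower number from compound 3 to compound 4 (0.12 log units; within the scatter), not clearly beyond the scatter, with wide uncertainty. Compound 4 is expected to give about 50000 nM in this assay, with a range from 10000 nM to 150000 nM.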

Compound 4, concentration for 50% growth inhibition: 9800 nM
Estimate against measurement, compound 4: 5.1-fold (0.71 log units) above, outside the stated range (below it).
By their numbers in this assay, from the lowest: compound 1; then compound 4; then compounds 3 and 2 (each within the scatter of the next).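

Working notes on the carbon with a double bond to nitrogen: the steps of a 6.7-fold lower number from compound 3 to compound 4 (0.82 log units; beyond the scatter) and a 6.9-fold lower number from compound 2 to compound 4 (0.84 log units; beyond the scatter) in this assay show that a ring without a hydroxyl can also give a clearly lower number than either chlorophenyl ring, so the low number at this place no longer rests on 2-hydroxyphenyl alone. Furan-2-yl does not close the whole gap, however: the step of a 2.6-fold higher number from compound 1 to compound 4 (0.42 log units; beyond the scatter) still lies beyond the scatter, and compound 1 keeps the lowest number of the four, with furan-2-yl sitting between 2-hydroxyphenyl and the chlorophenyl rings. No measurement on hand offers a reason for these steps.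

The exchange of 4-chlorophenyl for furan-2-yl loses the chlorine, shrinks the ring and brings in a ring oxygen all at once, and the compounds shown do not separate these changes; an unsubstituted phenyl or a thiophen-2-yl ring at this place would bear on that question. Also open, from the compounds shown here alone, is whether a methoxy group in place of the hydroxyl of compound 1 would keep a number as low as that ring gives.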